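This account rests on a few compounds, and the source may have more. Where it says the series, first, only, none or still open, it means among the compounds named here.

Compound 3 `CC(CCCCC(=O)NO)Nc1c(Nc2ccc(C(F)(F)F)cc2)c(=O)c1=O` is the reference here. In an ADME assay on cells (Hepatocyte, Homo sapiens) for pharmacokinetics, read by LC-MS, with a stated time of 90 min, tested at 1 uM (a lower number here means slower removal, a higher number faster removal of the compound), compound 3 gives 21 uL/min, the higher of the two numbers reported. Compound 1 `O=C(CCCCCNc1c(Nc2ccc(C(F)(F)F)cc2)c(=O)c1=O)NO` gives 11 uL/min. Compound 2 `Cc1ccc(Nc2c(NC(C)CCCCC(=O)NO)c(=O)c2=O)cc1` gives only a limit of the assay, < 6.5 uL/min. Compound 4 `CC(C)(CCCCC(=O)NO)Nc1c(Nc2ccc(C(F)(F)F)cc2)c(=O)c1=O` differs from compound 3 by methyl in place of hydrogen on a saturated chain carbon bound to a nitrogen on an aromatic ring and two saturated chain carbons. Among the compounds with values here, the one measured step of the same kind, a methyl added on a chain carbon, was a 1.9-fold higher number from compound 1 to compound 3 (0.28 log units; within the scatter), which stayed within the scatter; the step of an at least 3.2-fold higher number from compound 2 to compound 3 (0.50 log units; beyond the scatter) concerns the aromatic group and does not bear on this change. A small rise, or no change beyond the scatter, is therefore expected. Compound 4 is estimated at 27 uL/min, between 12 uL/min and 60 uL/min, an expected step of a 1.3-fold higher number from compound 3 to compound 4 (0.11 log units; within the scatter).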

Compound 4, intrinsic clearance in a liver preparation (reported as CLH), per the amount of preparation that the assay uses: 29 uL/min
For compound 4 the middle estimate is 1.1-fold (0.03 log units) below the measured one, and the stated range covers the measured number.
By their numbers in this assay, from the lowest: compounds 1, 3 and 4 (each within the scatter of the next, the first and the last beyond it). At a limit, below all of these: compound 2.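

A second methyl on this saturated chain carbon in this assay gives a 1.4-fold higher number from compound 3 to compound 4 (0.14 log units; within the scatter) and, like the first methyl (a 1.9-fold higher number from compound 1 to compound 3 (0.28 log units; within the scatter)), does not move the number beyond the scatter. Across both methyls together, however, compound 1 at 11 uL/min and compound 4 at 29 uL/min lie further apart than the scatter. Nothing measured here gives a cause for this. From the compounds shown here alone, it remains open how an ethyl group or an amine on this carbon would compare, and whether the second methyl would act alike with methyl in place of trifluoromethyl on the aromatic carbon.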